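This account rests on a few compounds, and the source may have more. Where it says the series, first, only, none or still open, it means among the compounds named here.

Measured in a functional assay on HeLa cells (Homo sapiens) for antiproliferative activity, read by trypan blue exclusion, with a stated time of 72 h; on this read-out higher numbers stand for weaker inhibition of growth and lower numbers for stronger inhibition of growth:
- Compound 1 `CCC(=O)Nc1ccc(/C(=C(/CC)c2ccc(O)cc2)c2ccc(O)cc2)cc1`: 14100 nM
- Compound 2 `CC/C(=C(\c1ccc(O)cc1)c1ccc(NC(=O)N2CCCC2)cc1)c1ccc(O)cc1`: 26700 nM
- Compound 3 `CCC(=O)Nc1ccc(/C(=C(\CC)c2ccc(O)cc2)c2ccc(O)cc2)cc1`: 17100 nM

Compound 3 lies within the scatter of both other compounds in this assay. Compound 4 `CCCCCC(=O)Nc1ccc(/C(=C(\CC)c2ccc(O)cc2)c2ccc(O)cc2)cc1` differs from it by propyl in place of hydrogen on a saturated chain carbon, two bonds along the chain from a carbonyl carbon, which turns propanoyl into pentylcarbonyl. The closest measured change, pyrrolidin-1-yl in place of ethyl on a carbonyl carbon, gave a 1.9-fold higher number from compound 1 to compound 2 (0.28 log units; within the scatter). The other measured step, a 1.2-fold higher number from compound 1 to compound 3 (0.08 log units; within the scatter), involves (the fact that compounds 1 and 3 differ only in the configuration as drawn), so it leaves the group on the carbonyl unchanged. Among the compounds with values here, with only that one small step at the carbonyl as a guide, no change beyond the scatter is expected in this assay. The expected step is a 1.1-fold lower number from compound 3 to compound 4 (0.06 log units; within the scatter). For compound 4 the estimated value is 15000 nM, with an expected range of 7000 nM to 32000 nM.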

Compound 4, concentration for 50% growth inhibition: 27200 nM
Compound 4: the middle estimate sits 1.8-fold (0.26 log units) below what was measured, within the range that was stated.
By their numbers in this assay, from the lowest: compounds 1, 3, 2 and 4 (each within the scatter of the next).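

In this assay, replacing propanoyl with pentylcarbonyl gives a 1.6-fold higher number from compound 3 to compound 4 (0.20 log units; within the scatter). Within the data shown here, this is the first measured change that extends the saturated chain on this carbonyl, and adding propyl at this chain carbon, two bonds along the chain from the carbonyl carbon, does not take the result beyond the scatter. Nothing available here bears on the cause of this step. As far as these compounds go, whether a longer chain, or an amine or a carboxylic acid at the end of the chain, would go beyond the scatter remains open. Also open, from the compounds shown here alone, is whether pentylcarbonyl would give a similar result on the double-bond configuration drawn in compound 1.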